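The source may report more compounds than this note shows. Statements on the series, on what has been measured and on what is new or still open speak of the compounds shown alone.

The series rests on the core of compound 1, `O=C(CCCCCCc1ccccc1)c1nncs1`. In an assay on HEK-293T cells for inhibition of diacylglycerol lipase-alpha (Homo sapiens), read by colorimetric assay (on this read-out higher numbers stand for weaker inhibition and lower numbers for stronger inhibition), compound 1 gives > 10000 nM, which is a limit of the assay and not a number. Compound 2, `O=C(CCCCCCc1ccccc1)c1nnc(-c2ccco2)s1`, carries furan-2-yl in place of hydrogen on an aromatic carbon of that core. In this assay compound 2 gives > 10000 nM, again a limit of the assay. The step that the two limits leave unreadable from compound 1 to compound 2 cannot be read, since (the limit of > 10000 nM in this assay, at which 2 of the 2 values shown sit). Compound 2 thus stands only at the limit, with no number beneath it on the values shown. Compound 3, `O=C(CCCCCCc1ccccc1)c1nnc(-c2cccs2)s1`, differs from compound 2 by thiophen-2-yl in place of furan-2-yl on an aromatic carbon. For the measured compounds named here, no measured step touches this exchange: the one step known, from compound 1 to compound 2, is unreadable. Nothing shown points to a change beyond the scatter in either direction, and nothing shown speaks for a value below the limit. Compound 3 is therefore expected to sit at the limit as well, with an estimate of 20000 nM, between 5000 nM and 100000 nM. The expected step is a step that the limit leaves unreadable from compound 2 to compound 3.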

Compound 3, half-maximal inhibitory concentration: > 10000 nM
Compound 3: only a limit was reported; the forecaster's own chance of this, stated with the estimate: 80%; the middle value lies beyond the limit too.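

No step among compound 1, compound 2 and compound 3 can be read, since all three sit at a limit of this assay and not at a number: the limit of > 10000 nM in this assay, at which 3 of the 3 values shown sit.

The compounds shown leave open whether any group at this place on the shared core gives a readable value, and how hydrogen, furan-2-yl and thiophen-2-yl rank against one another.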